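Ethoxy in place of ethylamino on a purine-like core

The source may report more compounds than this note shows. Statements on the series, on what has been measured and on what is new or still open speak of the compounds shown alone.

Measured so far:
compound 1 `CCNc1nc(N)c2nc(O)n(Cc3ccccc3)c2n1` — 1 uM
compound 2 `Nc1ncnc2c1nc(O)n2Cc1cccc2ccccc12` — 10 uM

Of the compounds shown here, two have been measured in a functional assay (spleen, spleen) for activation, with Mus musculus as the target; on this read-out lower numbers stand for an effect already at smaller amounts and higher numbers for an effect only at larger amounts of compound. Compound 1 gives 1 uM, the lower of the two numbers, so it acts at the smaller amount. Compound 2, with its different substitution, gives 10 uM, and this gap lies beyond the usual scatter of repeated measurements.

The unmeasured compound 3 `CCOc1nc(N)c2nc(O)n(Cc3ccccc3)c2n1` is built from compound 1 by a single exchange: ethoxy in place of ethylamino on an aromatic carbon. The change removes a hydrogen-bond donor and keeps the chain length, while the rest of the core is untouched.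

Among the measured compounds shown here, no measured pair in this set isolates this exchange, so its effect cannot be read off directly. With only compound 1 as an anchor, in this assay the step from compound 1 to compound 3 is expected to be small, with the estimate leaning slightly toward a lower number, expressed as a 2.0-fold lower number from compound 1 to compound 3 (0.30 log units; within the scatter). Compound 3 is therefore estimated at 0.5 uM, with a plausible range from 0.1 uM to 3 uM.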

Compound 3, minimum effective concentration: 0.1 uM
The estimate for compound 3 lay 5.0-fold (0.70 log units) above the measured number; the range from low to high includes it.
By their numbers in this assay, from the lowest: compound 3; then compound 1; then compound 2.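

In this assay, putting ethoxy in place of ethylamino on the aromatic carbon between two ring nitrogen atoms gives a 10-fold lower number from compound 1 to compound 3 (1.00 log units; beyond the scatter) and moves compound 3 to the lowest number of the set. Among the compounds shown here, this is the first sign that this position responds to the atom linking the two-carbon chain to the core: both groups have 3 heavy atoms, yet the exchange of nitrogen for oxygen, which goes from 1 hydrogen-bond donor to 0 hydrogen-bond donors, is enough to shift the read-out clearly. Nothing available here explains why the exchange has this effect, and this single pair cannot separate the role of the donor from that of the linking atom itself.

As far as these compounds go, it remains open whether a longer chain on the same oxygen, such as propoxy or butoxy, or a sulfur-linked ethylthio group would lower the number further or raise it again. From the compounds shown here alone, it is equally open whether a step of this size would hold with another group, such as a longer alkyl chain, in place of the benzyl group shared by compound 1 and compound 3.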